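The source may report more compounds than this note shows. Statements on the series, on what has been measured and on what is new or still open speak of the compounds shown alone.

Working notes on the series.

Compound 1 `CC(O)(CSc1ccc(S(F)(F)(F)(F)F)cc1)C(=O)Nc1cccc(S(F)(F)(F)(F)F)c1` is the reference thioether-type core bearing two pentafluorosulfanyl groups. In a functional assay on VCaP cells (Homo sapiens) for antiproliferative activity, read by propidium iodide staining, with a stated time of 96 h (a lower number here means a stronger inhibitor, a higher number a weaker inhibitor), compound 1 gives 24100 nM. Compound 2 `CC(O)(CSc1ccc(F)cc1)C(=O)Nc1cccc(S(F)(F)(F)(F)F)c1` differs from it by one fluorine atom in place of a group of 6 heavy atoms (5 fluorine, 1 sulfur; no ring), on an aromatic carbon; in this assay compound 2 gives 21900 nM. The step is a 1.1-fold lower number from compound 1 to compound 2 (0.04 log units; within the scatter), so this exchange leaves the read-out essentially unchanged between compound 1 and compound 2.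

Compound 3 `CC(O)(CS(=O)(=O)c1ccc(S(F)(F)(F)(F)F)cc1)C(=O)Nc1cccc(S(F)(F)(F)(F)F)c1` has a different core; the difference between the core of compound 3 and the core of compound 1 is not broken down here. In this assay compound 3 gives 17200 nM, which is within the scatter of both compound 1 and compound 2, so no order among the three can be stated.

Compound 4 `CC(O)(CS(=O)(=O)c1ccc(F)cc1)C(=O)Nc1cccc(S(F)(F)(F)(F)F)c1` is not yet measured. It differs from compound 3 by one fluorine atom in place of a group of 6 heavy atoms (5 fluorine, 1 sulfur; no ring), on an aromatic carbon, the same change as that from compound 1 to compound 2, at the same place. The step expected from compound 3 to compound 4 is therefore a 1.1-fold lower number from compound 3 to compound 4 (0.03 log units; within the scatter), resting on the precedent a 1.1-fold lower number from compound 1 to compound 2 (0.04 log units; within the scatter). For compound 4 the estimate in this assay is 16000 nM, with an expected range from 8000 nM to 32000 nM.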

Compound 4, half-maximal inhibitory concentration: 37900 nM
Compound 4: the middle estimate sits 2.4-fold (0.37 log units) below what was measured, outside the stated range (above it).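

In this assay, fluoro in place of pentafluorosulfanyl on the aromatic carbon gives a 2.2-fold higher number from compound 3 to compound 4 (0.34 log units; beyond the scatter), while the same exchange on the core of compound 1 gives a 1.1-fold lower number from compound 1 to compound 2 (0.04 log units; within the scatter). Set side by side, the two steps cannot be told apart: the same change on two cores in this assay, a 1.1-fold lower number (0.04 log units; within the scatter) from compound 1 to compound 2 and a 2.2-fold higher number (0.34 log units; beyond the scatter) from compound 3 to compound 4, 2.4-fold (0.38 log units) apart, within the scatter of two such steps

Going by these compounds alone, the series therefore gives no evidence that the outcome of this exchange depends on the core, although the step is beyond the scatter on only one of the two cores. Two pairs do not show that the step keeps one size from core to core, so its size on a further core remains uncertain.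

Left open is how a trifluoromethyl group or a chlorine atom on the same aromatic carbon would compare with fluoro and pentafluorosulfanyl on either core. Also open, on these data alone, is what a sulfoxide at the linking sulfur, or a nitrile in place of the pentafluorosulfanyl group on the other aromatic ring, would do to these steps.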